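Adding a bromo group to compound 2

This account rests on a few compounds, and the source may have more. Where it says the series, first, only, none or still open, it means among the compounds named here.

Compound 1 `CCOc1ccccc1-c1nnc(SCC(=O)c2ccccc2)o1`: 2670 nM
Compound 2 `COc1ccccc1-c1nnc(SCC(=O)c2ccccc2)o1`: 2070 nM

Among the measured compounds shown here, in a functional assay on MCF7 cells (Homo sapiens) for cytotoxicity, read by MTT assay and propidium iodide staining, with a stated time of 24 h (a lower number here means a stronger inhibitor, a higher number a weaker inhibitor), the only measured step is a 1.3-fold lower number from compound 1 to compound 2 (0.11 log units; within the scatter). That step lies within the scatter. For the measured compounds named here, compound 2 therefore stands level with the only other measured compound, and neither can be ranked above the other.

Compound 3 `COc1ccccc1-c1nnc(SCC(=O)c2ccc(Br)cc2)o1` differs from compound 2 in one place: phenyl becomes 4-bromophenyl, with bromo in place of hydrogen on an aromatic carbon. Going by the values given here, the one measured step changes a different part of the molecule, and no measured compound carries a group on this ring. The data therefore give no size or direction for this change, and nothing beyond the scatter is expected, though with real uncertainty. The expected step is a 1.0-fold lower number from compound 2 to compound 3 (0.01 log units; within the scatter). For compound 3 the estimated value is 2000 nM, with an expected range from 700 nM to 5500 nM.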

Compound 3, half-maximal inhibitory concentration: 600 nM
For compound 3 the middle estimate is 3.3-fold (0.52 log units) above the measured one; measured number outside the range, below it.
By their numbers in this assay, from the lowest: compound 3; then compounds 2 and 1 (each within the scatter of the next).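

Putting bromo in place of hydrogen on the phenyl group gives a 3.5-fold lower number from compound 2 to compound 3 (0.54 log units; beyond the scatter) in this assay and so marks a stronger inhibitor. This is the only step shown that lies beyond the scatter, so this position on the phenyl group, para to a large group, is the first place in the series where a change clearly moves the number. No other measurement shown explains why the number falls.

Among the compounds shown here, with bromo as the only group at this position, it remains open whether the gain is particular to bromo or would also appear with chloro, a methyl group, an amine or a carboxylic acid. On these data alone, it also remains open whether bromo elsewhere on the same ring would have a similar effect.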